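Hydroxyphenyl placement on the pyridine-free core: compound 4 outlook

The source may hold more compounds than are shown below. What is called first, only, known or untested is meant among the compounds shown, and "the series" means these compounds.

Measured so far:
compound 1 `Oc1ccc(-c2cc(-c3ccc(F)cc3)cc(-c3cccc(O)c3)n2)cc1` gives 5000 nM
compound 2 `Oc1cccc(-c2cc(-c3cccc(C(F)(F)F)c3)cc(-c3ccccc3O)n2)c1` gives 6340 nM
compound 3 `Oc1ccc(-c2cc(-c3cccc(C(F)(F)F)c3)cc(-c3ccccc3O)n2)cc1` gives > 50000 nM

All values come from a functional assay on T47D cells (Homo sapiens) for inhibition; a lower number here means a stronger inhibitor, a higher number a weaker inhibitor. For compound 3 the result is a limit only, > 50000 nM (the limit of > 50000 nM in this assay, at which 1 of the 3 values shown sits), so its true position in this assay is not pinned to a number. Compound 3 arises from compound 2 by an at least 7.8-fold higher number from compound 2 to compound 3 (0.89 log units; beyond the scatter): moving the hydroxyl from the 3-position to the 4-position on one arm cost activity here, beyond the scatter.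

The next compound, compound 4 `Oc1ccc(-c2cc(-c3cccc(C(F)(F)F)c3)cc(-c3cccc(O)c3)n2)cc1`, is not yet measured. It differs from compound 3 by 3-hydroxyphenyl in place of 2-hydroxyphenyl on an aromatic carbon. Among the compounds with values here, no measured pair covers exactly this exchange of 2-hydroxyphenyl for 3-hydroxyphenyl. Within the data shown here, the only step that bears on it indirectly is the one from compound 2 to compound 3, which shows that where the hydroxyl sits on one arm shifts the readout in this assay by a substantial margin. Compound 4 carries the same two hydroxyphenyl groups as compound 1, which lacks the 3-(trifluoromethyl)phenyl group, and compound 1 gives 5000 nM. Compound 2, with a 3-hydroxyphenyl arm, gives 6340 nM.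

On that basis compound 4 is expected to come back into the measurable range, with an estimated value of 8000 nM (range 2500 nM to 40000 nM). The implied step an at least 6.2-fold lower number from compound 3 to compound 4 (0.79 log units; beyond the scatter) is thus expected to be toward stronger inhibition, though a further limit result cannot be excluded.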

Compound 4, half-maximal inhibitory concentration: 2630 nM
Estimate against measurement, compound 4: 3.0-fold (0.48 log units) above, within the range that was stated.
By their numbers in this assay, from the lowest: compounds 4, 1 and 2 (each within the scatter of the next, the first and the last beyond it). At a limit, above all of these: compound 3.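

The exchange of 2-hydroxyphenyl for 3-hydroxyphenyl next to the ring nitrogen gives an at least 19-fold lower number from compound 3 to compound 4 (1.27 log units; beyond the scatter) in this assay, and the size of this step is only a bound, as compound 3 is a limit and not a number: the limit of > 50000 nM in this assay, at which 1 of the 4 values shown sits.

With the 3-hydroxyphenyl arm kept, 4-hydroxyphenyl in place of 2-hydroxyphenyl gives a 2.4-fold lower number from compound 2 to compound 4 (0.38 log units; beyond the scatter), a far smaller step, so the effect of a group at this position depends on the other hydroxyphenyl arm; of the four compounds, only compound 3 has no 3-hydroxyphenyl group, and only compound 3 stands at a limit. The exchange of 4-fluorophenyl for 3-(trifluoromethyl)phenyl gives a 1.9-fold lower number from compound 1 to compound 4 (0.28 log units; within the scatter), so with this pair of hydroxyphenyl arms that change cannot be told from the scatter in this assay.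

From the compounds shown here alone, it remains open whether the free hydroxyl of the 3-hydroxyphenyl group is itself required, or whether a methoxy group, an amine or a carboxylic acid could stand in its place. The compounds shown also leave open how a core carrying two 3-hydroxyphenyl arms would read out in this assay.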